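The source may report more compounds than this note shows. Statements on the series, on what has been measured and on what is new or still open speak of the compounds shown alone.

Compounds measured in an ADME assay on microsomes from liver (Homo sapiens) for metabolic stability, read by LC-MS, tested at 1 uM; a lower number here means slower removal, a higher number faster removal of the compound:
- compound 1 `N[C@H]1CC[C@@H](Oc2ccc([C@H]3CC[C@]4(CC3)OOC3(O4)C4CC5CC(C4)CC3C5)cc2)CC1` gives < 7 mL.min-1.g-1, a limit of the assay
- compound 2 `c1cc([C@H]2CC[C@]3(CC2)OOC2(O3)C3CC4CC(C3)CC2C4)ccc1OCC1CCNCC1` gives < 7 mL.min-1.g-1, a limit of the assay
- compound 3 `CC(C)(CN)Oc1ccc([C@H]2CC[C@]3(CC2)OOC2(O3)C3CC4CC(C3)CC2C4)cc1` gives < 7 mL.min-1.g-1, a limit of the assay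

All three share the same core and differ only in the group on the oxygen on the aromatic ring. Compound 1 stands at the lower limit of this assay, with no number to place it against the others. The steps from compound 1 to compound 2 a step that the two limits leave unreadable from compound 1 to compound 2, from compound 1 to compound 3 a step that the two limits leave unreadable from compound 1 to compound 3 and from compound 2 to compound 3 a step that the two limits leave unreadable from compound 2 to compound 3 are all left unreadable because of the limit of < 7 mL.min-1.g-1 in this assay, at which 3 of the 3 values shown sit.

Compound 4 `O=S(=O)(c1ccc([C@H]2CC[C@]3(CC2)OOC2(O3)C3CC4CC(C3)CC2C4)cc1)N1CCNCC1` is not yet measured. Its change from compound 1 is (piperazin-1-yl)sulfonyl in place of (4-aminocyclohexyl)oxy on an aromatic carbon. Among the compounds with values here, none of the measured steps touches a sulfonyl or a piperazine, and none has a readable size; the only bearing they have is that three different groups on the oxygen all left the read-out at the limit. No step beyond the scatter is therefore expected in this assay, in either direction. Compound 4 is estimated at 5 mL.min-1.g-1 in this assay, within 2 mL.min-1.g-1 to 12 mL.min-1.g-1, so the expected step from compound 1 is a step that the limit leaves unreadable from compound 1 to compound 4, most likely again reported only as a limit.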

Compound 4, intrinsic clearance in microsomes: 16 mL.min-1.g-1
Compound 4: middle estimate off by 3.2-fold (0.51 log units), on the low side; the whole stated range lies below it.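

Setting (piperazin-1-yl)sulfonyl on the aromatic carbon in place of (4-aminocyclohexyl)oxy gives the first change at this position that moves the read-out in this assay off the limit, with an at least 2.2-fold higher number from compound 1 to compound 4 (0.35 log units; beyond the scatter). The same direction appears against the other two groups joined through oxygen, with an at least 2.2-fold higher number from compound 2 to compound 4 (0.35 log units; beyond the scatter) for (piperidin-4-yl)methoxy and an at least 2.2-fold higher number from compound 3 to compound 4 (0.35 log units; beyond the scatter) for 1-(aminomethyl)-1-methylethoxy, so this position can alter the read-out, although the three steps give only a minimum size. The steps among the three oxygen-linked compounds still cannot be read, and these compounds cannot be ranked against one another: the limit of < 7 mL.min-1.g-1 in this assay, at which 3 of the 4 values shown sit.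

The change replaces the oxygen link and the ring in a single move, and the compounds shown leave open whether the higher number goes with the sulfonyl or with the piperazine. On these data alone, a morpholine on the sulfonyl, or a piperazine joined through an oxygen, would separate the two, and the values such compounds would give in this assay remain open.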